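A few compounds are considered here, and "the series" means these few. Any claim that something is new, unique, unknown or untested is made for them only; others in the source may bear on it.

Compound 1 `O=C1N(Cc2ccc(Cl)cc2)CCC12CCNCC2`: < 20%
Compound 2 `O=C1N(Cc2ccc(Cl)cc2)CCC12CCN(Cc1ccc(F)cc1)CC2`: 65%

Among the compounds with values here, in a functional assay on cells for antagonist activity at Voltage-dependent T-type calcium channel subunit alpha-1H (Homo sapiens), read by patch clamp, tested at 3 uM (a higher number here means more inhibition at the concentration tested (going by the name of the read-out), a lower number less inhibition), compound 2 gives 65%, the only plain number among the two measured compounds. Compound 1, which carries a hydrogen on the amine nitrogen in the ring, sits at a limit of the assay rather than at a number, (the limit of < 20% in this assay, at which 1 of the 2 values shown sits). Within the data shown here, the one measured step, a number at least 45 percentage points higher from compound 1 to compound 2 (beyond the scatter), is large and shows that a benzyl group on that nitrogen matters for inhibition. Compound 3 `CCOc1ccccc1CN1CCC2(CC1)CCN(Cc1ccc(Cl)cc1)C2=O` keeps that benzyl group and differs from compound 2 only by 2-ethoxyphenyl in place of 4-fluorophenyl on a saturated chain carbon bound to an amine nitrogen in a ring. Among the measured compounds shown here, no measured step exchanges one aryl group for another, so the single known step bears only indirectly on this change; the expectation is therefore a step of a number 5 percentage points lower from compound 2 to compound 3 (within the scatter), within the scatter. Compound 3 is estimated at 60%, with a range from 30% to 85%.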

Compound 3, a percentage reported as inhibition, at one concentration (the size of the read-out at that concentration, not a potency): 67%
Beside the measured number, compound 3's estimate is 7 percentage points below it, within the range that was stated.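

Exchanging 4-fluorophenyl for 2-ethoxyphenyl on a saturated chain carbon bound to an amine nitrogen in a ring gives a number 2 percentage points higher from compound 2 to compound 3 (within the scatter) in this assay, so the two compounds cannot be told apart in this test. Within the data shown here, the earlier compounds showed only that adding a benzyl group to the nitrogen matters; this result shows that the aryl part of that group can take more than one form, here including one with an added oxygen, without a measurable loss of inhibition. Nothing in the data shown explains why the two aryl groups give such similar numbers.

Still open, going by these compounds, is whether an aromatic ring is needed here at all, which a cyclohexyl or a pyridine ring in its place would help to answer. Compound 2 and compound 3 also cannot show whether the ethoxy group itself contributes anything, since an unsubstituted phenyl is not among the compounds shown.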